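The source may report more compounds than this note shows. Statements on the series, on what has been measured and on what is new or still open speak of the compounds shown alone.

Of the compounds shown here, three built on a shared core have been measured in a functional assay on CCRF-CEM cells (Homo sapiens) for antiproliferative activity, with a stated time of 72 h; a higher number here means a weaker inhibitor, a lower number a stronger inhibitor. Compound 1 `OC[C@H]1O[C@@H](n2cnc3c(NCc4ccccc4F)ncnc32)[C@H](O)[C@@H]1O` gives 4600 nM, compound 2 `OC[C@H]1O[C@@H](n2cnc3c(NCc4cccc(F)c4)ncnc32)[C@H](O)[C@@H]1O` gives 4000 nM, and compound 3 `OC[C@H]1O[C@@H](n2cnc3c(NCc4ccc(Cl)cc4)ncnc32)[C@H](O)[C@@H]1O` gives 10200 nM, the highest of the three numbers. The steps of a 2.2-fold higher number from compound 1 to compound 3 (0.35 log units; beyond the scatter) and a 2.6-fold higher number from compound 2 to compound 3 (0.41 log units; beyond the scatter) show that 4-chlorophenyl on a saturated chain carbon bound to a nitrogen on an aromatic ring carries a modestly higher number than either fluorophenyl, while a 1.2-fold lower number from compound 1 to compound 2 (0.06 log units; within the scatter) lies within the scatter. Compound 4 `OC[C@H]1O[C@@H](n2cnc3c(NCc4ccc(F)c(F)c4F)ncnc32)[C@H](O)[C@@H]1O` differs from compound 3 by 2,3,4-trifluorophenyl in place of 4-chlorophenyl on a saturated chain carbon bound to a nitrogen on an aromatic ring. Because fluorophenyl groups gave the lower numbers in a 2.2-fold higher number from compound 1 to compound 3 (0.35 log units; beyond the scatter), a modest move toward a lower number is expected. Compound 4 is estimated at 5000 nM, within 2000 nM to 12000 nM, an expected step of a 2.0-fold lower number from compound 3 to compound 4 (0.31 log units; beyond the scatter).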

Compound 4, half-maximal inhibitory concentration: 58200 nM
For compound 4 the middle estimate is 12-fold (1.07 log units) below the measured one; measured number outside the range, above it.
By their numbers in this assay, from the lowest: compounds 2 and 1 (each within the scatter of the next); then compound 3; then compound 4.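

The lower numbers of the 2-fluorophenyl and 3-fluorophenyl groups do not carry over to 2,3,4-trifluorophenyl on a saturated chain carbon bound to a nitrogen on an aromatic ring: the change brings a 13-fold higher number from compound 1 to compound 4 (1.10 log units; beyond the scatter) and a 15-fold higher number from compound 2 to compound 4 (1.16 log units; beyond the scatter) in one direction. The group also falls behind 4-chlorophenyl, with a 5.7-fold higher number from compound 3 to compound 4 (0.76 log units; beyond the scatter) making compound 4 the weakest of the four, so fluorine on this ring does not by itself go with a lower number. The compounds shown leave open how an unsubstituted phenyl, a methoxyphenyl or a longer chain would fare here, and which of the added fluorines carries the rise. Nothing at hand gives a reason for the rise.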